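A few compounds are considered here, and "the series" means these few. Any claim that something is new, unique, unknown or untested is made for them only; others in the source may bear on it.

Within the data shown here, compound 2 `CCCC(=O)OCCOC(=O)c1ccc(C(=O)Nc2ccc3c(c2)C(C)(C)CCC3(C)C)cc1` is the one member of the pair that returns a number in a functional assay on NB-4 cells (Homo sapiens) for inhibition, read by MTT assay, with a stated time of 48 h; on this read-out lower numbers stand for stronger inhibition and higher numbers for weaker inhibition: compound 2 gives 11000 nM. Compound 1 `CCCC(CCC)C(=O)OCCCCOC(=O)c1ccc(C(=O)Nc2ccc3c(c2)C(C)(C)CCC3(C)C)cc1` returns only a limit in this assay, > 1000000 nM. Among the measured compounds shown here, the single measured step, an at least 90-fold lower number from compound 1 to compound 2 (1.95 log units; beyond the scatter), therefore rests on the limit of > 1000000 nM in this assay, at which 1 of the 2 values shown sits, and its size is known only as a lower bound. Compound 3 `CCCC(=O)OCCCOC(=O)c1ccc(C(=O)Nc2ccc3c(c2)C(C)(C)CCC3(C)C)cc1` differs from compound 2 by ((propylcarbonyl)oxy)methyl in place of (propylcarbonyl)oxy on a saturated chain carbon, two bonds along the chain from an oxygen next to a carbonyl group. The measured step lengthens the same chain but changes the acyl end at the same time, so it gives no clean size for one added chain carbon alone; what it does point to is that the longer linker reads weaker, with only compound 1 and compound 2 behind that reading. For compound 3 the expected step is a 2.3-fold higher number from compound 2 to compound 3 (0.36 log units; beyond the scatter), a modest move toward weaker inhibition. Compound 3 is thus estimated at 25000 nM in this assay, with a range from 8000 nM to 120000 nM.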

Compound 3, half-maximal inhibitory concentration: 5750 nM
For compound 3 the middle estimate is 4.3-fold (0.64 log units) above the measured one; measured number below the stated range.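

In this assay, the step from the two-carbon to the three-carbon linker, a 1.9-fold lower number from compound 2 to compound 3 (0.28 log units; within the scatter), shows that ((propylcarbonyl)oxy)methyl in place of (propylcarbonyl)oxy at this saturated chain carbon leaves the read-out unresolved from compound 2, so adding this chain carbon alone gives no sign of weaker inhibition. The large gap remains with an at least 170-fold lower number from compound 1 to compound 3 (2.24 log units; beyond the scatter), which combines a longer chain with a change at the acyl end. Compound 1 gives only a limit, so this step is a lower bound: the limit of > 1000000 nM in this assay, at which 1 of the 3 values shown sits.

From the compounds shown here alone, it remains open how much of that gap belongs to the 1-propylbutyl end and how much to the longer linker. Also open, going by these compounds, is whether a longer chain, an amine or a carboxylic acid at the (propylcarbonyl)oxy end would keep this level.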